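This account rests on a few compounds, and the source may have more. Where it says the series, first, only, none or still open, it means among the compounds named here.

Measured in an ADME assay on T29 cells (Homo sapiens) for cytotoxicity, read by sulforhodamine B assay, with a stated time of 3 days; a lower number here means a stronger inhibitor, a higher number a weaker inhibitor:
- compound 1 `OCc1cn(Cc2ccc(Cl)cc2)c2ccc(F)cc12`: 8120 nM
- compound 2 `OCc1cn(Cc2ccc(Cl)cc2)c2ccc(Cl)cc12`: > 31600 nM (a limit of the assay)

Within the data shown here, the only result for compound 2 in this assay is > 31600 nM, which is a limit and not a measured number. Compound 3 `COc1ccc2c(c1)c(CO)cn2Cc1ccc(Cl)cc1` differs from it by methoxy in place of chloro on an aromatic carbon.

Among the measured compounds shown here, one measured step bears on this carbon: an at least 3.8-fold higher number from compound 1 to compound 2 (0.59 log units; beyond the scatter). For the measured compounds named here, it shows that the number can move with the group at this carbon, but it involves no methoxy compound. In this assay compound 3 is therefore expected to give a lower number than compound 2, with a result at the limit still possible. The expected change is an at least 1.9-fold lower number from compound 2 to compound 3 (0.29 log units; that floor lies within the scatter). For compound 3 the estimated value is 16000 nM, with an expected range of 5000 nM to 40000 nM.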

Compound 3, half-maximal inhibitory concentration: > 31600 nM
Compound 3 was reported as a limit (the forecaster's own chance of this, stated with the estimate: 35%); middle value at least 1.9-fold (0.29 log units) away from the limit.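

In this assay, among these compounds, methoxy in place of fluoro on this aromatic carbon gives an at least 3.8-fold higher number from compound 1 to compound 3 (0.59 log units; beyond the scatter), so a second group now gives a higher number than fluoro, and fluoro remains the only group here with a measured number. Compound 3 gives > 31600 nM, which is a limit. Chloro and methoxy cannot be ordered, and the step between compound 2 and compound 3 cannot be read: the limit of > 31600 nM in this assay, at which 2 of the 3 values shown sit.

From the compounds shown here alone, how far the true values of compound 2 and compound 3 lie past their limits stays open, and so does any difference between them. Among the compounds shown here, also open is whether an amine or a carboxylic acid on this aromatic carbon would give a measured number in this assay, and how that number would compare with the one for compound 1.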